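Swapping Methoxy for Fluoro on a Shared Core

The source may hold more compounds than are shown below. What is called first, only, known or untested is meant among the compounds shown, and "the series" means these compounds.

Three compounds built on one shared core have been run in a functional assay on the whole organism for inhibition, with Rattus norvegicus as the target, read by paw edema, with a stated time of 30 min, at a dose of 40 mg/kg by the oral route; on this read-out higher numbers stand for a stronger effect at the one dose given and lower numbers for a weaker effect. Compound 1 `COc1ccc(OCC2=NCCO2)cc1` gives 33.2%, the second highest of the three numbers. Compound 2 `Clc1ccccc1OCC1=NCCO1` gives 22.2% in this assay, a number that lies beyond the usual scatter below compound 1. Compound 3 `Cc1cccc(OCC2=NCCO2)c1` gives 44.6% in this assay, lying beyond the scatter above compound 1. Compound 1 thus sits in the middle, separated from each neighbour by more than the scatter allows.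

Compound 4 `Fc1ccc(OCC2=NCCO2)cc1` has not yet been measured. Its difference from compound 1 is fluoro in place of methoxy on an aromatic carbon. Within the data shown here, no two measured compounds differ in a single place, so no earlier step of this kind exists to guide the forecast, and the fluoro group appears in none of the measured compounds. The step is therefore expected to be small, a number 2.2 percentage points lower from compound 1 to compound 4 (within the scatter), with no clear direction beyond the scatter. Compound 4 is estimated to give 31% in this assay, with a range from 16% to 46%.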

Compound 4, a percentage reported as inhibition, in the whole organism at one dose (the size of the read-out at that dose, not a potency): 30.2%
Compound 4: middle estimate off by 0.8 percentage points, on the high side, and the stated range covers the measured number.
By their numbers in this assay, from the lowest: compounds 2, 4 and 1 (each within the scatter of the next, the first and the last beyond it); then compound 3.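

In this assay, among these compounds, the first step on this shared core that can be read in one place is a number 3 percentage points lower from compound 1 to compound 4 (within the scatter), with fluoro in place of methoxy on an aromatic carbon. Methoxy counts 2 heavy atoms and 1 hydrogen-bond acceptor and fluoro counts 1 heavy atom and 0 hydrogen-bond acceptors, yet at this position and this one dose the swap cannot be told apart from ordinary scatter. No measurement at hand says why the two groups read alike.

The compounds shown leave open whether any group at this aromatic carbon can move the number beyond the scatter, for instance an amine, a carboxylic acid or a longer alkoxy chain. A single dose also leaves open whether the two compounds would still match at other doses.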